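Swapping the heteroaryl on the sulfonamide nitrogen of compound 2

The source may hold more compounds than are shown below. What is called first, only, known or untested is meant among the compounds shown, and "the series" means these compounds.

Measured compounds:
Compound 1 `O=C(Nc1ccccc1)Nc1ccc(S(=O)(=O)Nc2ccnc3cc(C(F)(F)F)ccc23)cc1` gives 25400 nM in a functional assay on HT-1080 cells (Homo sapiens) for antiproliferative activity, read by sulforhodamine B assay, with a stated time of 48 h; a higher number here means a weaker inhibitor, a lower number a stronger inhibitor.
Compound 2 `Cc1noc(NS(=O)(=O)c2ccc(N/C(S)=N\c3ccnc4cc(C(F)(F)F)ccc34)cc2)c1C` gives 27700 nM in this assay.
Compound 3 `O=S(=O)(Nc1ccccn1)c1ccc(N/C(S)=N\c2ccnc3cc(C(F)(F)F)ccc23)cc1` gives 28000 nM in this assay.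

All three numbers sit close together. Compound 2 lies between the other two, yet both neighbours are within the scatter of it, so the three compounds cannot be told apart on these data.

Compound 4 `Cc1cc(C)nc(NS(=O)(=O)c2ccc(N/C(S)=N\c3ccnc4cc(C(F)(F)F)ccc34)cc2)n1` is not yet measured. It differs from compound 2 in one place: 4,6-dimethylpyrimidin-2-yl in place of 3,4-dimethyl-1,2-oxazol-5-yl on a sulfonamide nitrogen. Among the measured compounds shown here, the one measured step that bears on this is the exchange of the same group on the same sulfonamide nitrogen, a 1.0-fold higher number from compound 2 to compound 3 (0.00 log units; within the scatter), which left the number unchanged. Compound 1, with a quite different linker, also sits in the same range. For the measured compounds named here, the only precedent therefore says that what hangs on the sulfonamide nitrogen does little here, and no step beyond the scatter is expected from compound 2 to compound 4 in this assay: a 1.0-fold lower number from compound 2 to compound 4 (0.01 log units; within the scatter). Compound 4 is estimated at 27000 nM, with a range from 12000 nM to 60000 nM.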

Compound 4, half-maximal inhibitory concentration: 29500 nM
The estimate for compound 4 lay 1.1-fold (0.04 log units) below the measured number; low and high end bracket the measured number.
By their numbers in this assay, from the lowest: compounds 1, 2, 3 and 4 (each within the scatter of the next).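

In this assay, 4,6-dimethylpyrimidin-2-yl in place of 3,4-dimethyl-1,2-oxazol-5-yl on the sulfonamide nitrogen gives a 1.1-fold higher number from compound 2 to compound 4 (0.03 log units; within the scatter), and the same group in place of pyridin-2-yl gives a 1.1-fold higher number from compound 3 to compound 4 (0.02 log units; within the scatter). Among the compounds shown here, compounds 2, 3 and 4 therefore cannot be told apart, now across a five-membered ring and two six-membered rings, with and without methyl groups, so the flat result from the single earlier step holds for a third aromatic group. No measurement here offers a reason for this flat result.

All three of these compounds carry an aromatic ring on this nitrogen, so it remains open whether a non-aromatic group, such as a simple alkyl chain, a morpholine or a chain ending in a carboxylic acid, would move the number. As far as these compounds go, compound 1 differs from them in more than one place, so the part played by the rest of the molecule also stays open.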